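This account rests on a few compounds, and the source may have more. Where it says the series, first, only, none or still open, it means among the compounds named here.

Compound 1 has the structure `Cn1c(SCc2ccccc2)nnc1-c1cc([N+](=O)[O-])cc([N+](=O)[O-])c1`, and compound 2 has the structure `CCCCCCn1c(SCc2ccccc2)nnc1-c1cc([N+](=O)[O-])cc([N+](=O)[O-])c1`. Both were tested in an ADME assay on HepG2 cells (Homo sapiens) for cytotoxicity, with a stated time of 48 h; on this read-out higher numbers stand for weaker inhibition and lower numbers for stronger inhibition. In this assay compound 1 gives > 30000 nM, which is a limit of the assay and not a number. In this assay compound 2 gives > 30000 nM, again a limit rather than a number. The change from compound 1 to compound 2 is pentyl in place of hydrogen on a saturated chain carbon bound to an aromatic nitrogen, and the step it made in this assay is a step that the two limits leave unreadable from compound 1 to compound 2, so the two limits leave its size unreadable.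

Compound 3, with the structure `CCCSc1nnc(-c2cc([N+](=O)[O-])cc([N+](=O)[O-])c2)n1Cc1ccccc1`, carries a different core; how the core of compound 3 differs from the core of compound 1 is not broken down here. In this assay compound 3 gives > 30000 nM, which is a limit and not a number. All three measured values therefore sit at the limit of > 30000 nM in this assay, at which 3 of the 3 values shown sit.

Compound 4, with the structure `CCCCCCCCSc1nnc(-c2cc([N+](=O)[O-])cc([N+](=O)[O-])c2)n1Cc1ccccc1`, has not yet been measured in this assay. It differs from compound 3 by pentyl in place of hydrogen on a saturated chain carbon, three bonds along the chain from a sulfur. Among the compounds with values here, this is the same kind of change as the one from compound 1 to compound 2, though the place is not the same: there the pentyl entered on a saturated chain carbon bound to an aromatic nitrogen, here on a saturated chain carbon, three bonds along the chain from a sulfur. Within the data shown here, because every value so far sits at the limit of > 30000 nM in this assay, at which 3 of the 3 values shown sit, the step from compound 3 to compound 4 is expected to be a step that the limit leaves unreadable from compound 3 to compound 4. Compound 4 is thus estimated to give 40000 nM in this assay, and most probably the assay will once more report only a limit.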

Compound 4, half-maximal inhibitory concentration: > 30000 nM
Compound 4 was reported as a limit; the forecaster's own chance of this, stated with the estimate: 85%; the middle value is on the limit's open side.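

No new step can be read from this result: compound 3 and compound 4 both stand only as limits in this assay, so the size of the step between them stays unreadable, and the values shown give: the limit of > 30000 nM in this assay, at which 4 of the 4 values shown sit.

The compounds shown leave open at what concentration any of them would reach half-maximal inhibition, and whether either pentyl change alters that concentration at all.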